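This account rests on a few compounds, and the source may have more. Where it says the series, first, only, none or still open, it means among the compounds named here.

Measured in an ADME assay on BSC-1 cells (Chlorocebus aethiops) for cytotoxicity, read by luminescence and ATP content, with a stated time of 4 days; a lower number here means that less compound is tolerated, a higher number that more compound is tolerated:
- compound 1 `CCCOCCCCCCCCCc1cc2cn([C@@H]3CC[C@H](CO)O3)c(=O)nc2o1`: 89100 nM
- compound 2 `CCCCOCCCCCCCCCc1cc2cn([C@@H]3CC[C@H](CO)O3)c(=O)nc2o1`: > 100000 nM (a limit)
- compound 3 `CCCCCOCCCCCCCCCc1cc2cn([C@@H]3CC[C@H](CO)O3)c(=O)nc2o1`: > 100000 nM (a limit)

Compound 2 gives only a limit, not a number. It stands at the limit of > 100000 nM in this assay, at which 2 of the 3 values shown sit.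

The change to compound 4 `CCCCCCOCCCCCCCCCc1cc2cn([C@@H]3CC[C@H](CO)O3)c(=O)nc2o1` is this: ethyl in place of hydrogen on a saturated chain carbon, four bonds along the chain from an oxygen on a saturated carbon. Ethyl takes the place of hydrogen on a saturated chain carbon, four bonds along the chain from an oxygen on a saturated carbon.

The closest measured change puts methyl at that same place, giving a step that the two limits leave unreadable from compound 2 to compound 3. The other two measured steps are an at least 1.1-fold higher number from compound 1 to compound 2 (0.05 log units; that floor lies within the scatter) and an at least 1.1-fold higher number from compound 1 to compound 3 (0.05 log units; that floor lies within the scatter). Neither shows a change beyond the scatter, so none is expected here in this assay. The expected change is a number no higher from compound 2 to compound 4 (the limit leaves the size open).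

For compound 4 the estimate is 100000 nM, with an expected range of 50000 nM to 200000 nM.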

Compound 4, half-maximal cytotoxic concentration: 74100 nM
For compound 4 the middle estimate is 1.3-fold (0.13 log units) above the measured one; measured number inside the range.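

In this assay, ethyl at this place gives a measured number rather than a limit, and the floor of each step lies within the scatter: an at least 1.3-fold lower number from compound 2 to compound 4 (0.13 log units; that floor lies within the scatter), and an at least 1.3-fold lower number from compound 3 to compound 4 (0.13 log units; that floor lies within the scatter). Propyl at the place three bonds along the chain gives a 1.2-fold lower number from compound 1 to compound 4 (0.08 log units; within the scatter), also within the scatter. So neither change has yet shown a difference beyond the scatter, and the two cores leave the direction unsettled: the same change on two cores in this assay, an at least 1.1-fold higher number (0.05 log units; that floor lies within the scatter) from compound 1 to compound 3 and an at least 1.3-fold lower number (0.13 log units; that floor lies within the scatter) from compound 2 to compound 4; the limit leaves it open whether they differ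

Compounds 2 and 3 remain limits, so their true numbers are open. Also open, from the compounds shown here alone, is whether an amine or a carboxylic acid in place of this ethyl would shift the tolerated concentration beyond the scatter.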